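From 2-phenylethenyl to phenethyl in compound 2

The source may report more compounds than this note shows. Statements on the series, on what has been measured and on what is new or still open speak of the compounds shown alone.

- Compound 1 `C(=C/C=C/c1ccccc1)\C=C\Cc1ccccc1`: 840 nM
- Compound 2 `CC(=O)Oc1ccc(CC[C@@H](O)CC/C=C/c2ccccc2)cc1OC(C)=O`: 1610 nM

In a functional assay on RAW264.7 cells (Mus musculus) for inhibition, read by Griess assay, with stated times of 2 h and 24 h (on this read-out higher numbers stand for weaker inhibition and lower numbers for stronger inhibition), compound 2 gives 1610 nM, which lies within the usual scatter of compound 1 at 840 nM, so the two cannot be told apart. Compound 3 `CC(=O)Oc1ccc(CC[C@@H](O)CCCCc2ccccc2)cc1OC(C)=O` differs from compound 2 in one place: phenethyl in place of 2-phenylethenyl on a saturated chain carbon, three bonds along the chain from an oxygen on a saturated carbon. This puts phenethyl in place of 2-phenylethenyl on a saturated chain carbon. Among the measured compounds shown here, no measured pair shows the effect of this change, so no step beyond the scatter is expected in this assay. The expected step is a 1.1-fold lower number from compound 2 to compound 3 (0.03 log units; within the scatter). Compound 3 is estimated at 1500 nM, with an expected range from 700 nM to 3200 nM.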

Compound 3, half-maximal inhibitory concentration: 330 nM
For compound 3 the middle estimate is 4.5-fold (0.66 log units) above the measured one, and the stated range ends above it.
By their numbers in this assay, from the lowest: compound 3; then compounds 1 and 2 (each within the scatter of the next).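

In this assay, phenethyl in place of 2-phenylethenyl on this saturated chain carbon gives a 4.9-fold lower number from compound 2 to compound 3 (0.69 log units; beyond the scatter). The two groups differ only by the double bond outside the aromatic ring, so this position responds to the loss of that one double bond. Nothing measured here explains the step.

Still open, from the compounds shown here alone, is whether a longer chain, an amine or a carboxylic acid at this same place would lower the number further. Also open, going by these compounds, is whether the same change would give a similar step on a different core.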